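The source may report more compounds than this note shows. Statements on the series, on what has been measured and on what is new or still open speak of the compounds shown alone.

Measured compounds:
- compound 1, `Cc1ccc(CNC(=O)c2nn(-c3ccc(F)cc3)c(OC[C@@H](O)C[C@@H](O)CC(=O)O)c2C(C)C)cc1`, giving 2110 nM in a functional assay on L6 cells (Rattus norvegicus) for inhibition; a lower number here means a stronger inhibitor, a higher number a weaker inhibitor
- compound 2, `COc1ccc(CNC(=O)c2nn(-c3ccc(F)cc3)c(OC[C@@H](O)C[C@@H](O)CC(=O)O)c2C(C)C)cc1`, for which compound 2 has "not determined" (no result reported) in this assay
- compound 3, `CC(C)c1c(C(=O)NCc2ccc(Cl)cc2)nn(-c2ccc(F)cc2)c1OC[C@@H](O)C[C@@H](O)CC(=O)O`, for which compound 3 has "not determined" (no result reported) in this assay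

Going by the values given here, compound 1 is the only one of the three with a number in this assay; compound 2 and compound 3 carry no result there, so no comparison between measured compounds can be drawn, and compound 1 stands alone as the reference point for what follows.

The unmeasured compound 4, `CC(C)c1c(C(=O)N(C)Cc2cccc(Cl)c2)nn(-c2ccc(F)cc2)c1OC[C@@H](O)C[C@@H](O)CC(=O)O`, differs from compound 1 in one place:
(3-chlorobenzyl)(methyl)amino in place of (4-methylbenzyl)amino on a carbonyl carbon

Among the compounds with values here, with no step between measured compounds available, the size of the change can only be expected, not read off. The loss of the amide hydrogen-bond donor together with the move from 4-methylbenzyl to 3-chlorobenzyl is a combined change of two parts, and a shift beyond the usual scatter in this assay is expected, most likely toward a weaker inhibitor, though a move in the other direction cannot be ruled out from the data shown. Compound 4 is therefore expected to give about 4500 nM in this assay, within a range from 1200 nM to 18000 nM. The expected step of a 2.1-fold higher number from compound 1 to compound 4 (0.33 log units; beyond the scatter) thus lies toward weaker inhibition.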

Compound 4, half-maximal inhibitory concentration: 2120 nM
Estimate against measurement, compound 4: 2.1-fold (0.33 log units) above; the range from low to high includes it.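

In this assay, placing (3-chlorobenzyl)(methyl)amino in place of (4-methylbenzyl)amino on the carbonyl carbon gives a 1.0-fold higher number from compound 1 to compound 4 (0.00 log units; within the scatter), so the two compounds cannot be told apart in this read-out. Going by these compounds alone, this is the first comparison available at this position, and it shows that a compound without the amide hydrogen, and with a different substituted benzyl group, can match compound 1 within the scatter; at this level of inhibition, then, the amide hydrogen is not needed in this particular combination of groups. Nothing shown gives a measured reason for this match.

The exchange combines two differences, so the compounds shown leave open whether the added methyl on the amide nitrogen and the change from 4-methylbenzyl to 3-chlorobenzyl are each without consequence or offset one another, a question that the secondary amide carrying 3-chlorobenzyl or the tertiary amide carrying 4-methylbenzyl would separate. They also leave open how far this position extends its tolerance to groups of another kind, such as a 2-phenylethyl chain, a morpholine amide or a carboxylic acid on the benzyl ring.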